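The source may hold more compounds than are shown below. What is called first, only, known or untested is meant among the compounds shown, and "the series" means these compounds.

Compound 2 `Cc1cc(S(C)(=O)=O)c(NC(=O)N(Cc2ccc(Oc3ccc(F)cc3)cc2)C2CCCCCC2)c(Cl)n1` stands at > 0.1 mg/kg in a functional assay on the whole organism with Rattus norvegicus as the target (a higher number here means that more compound is needed for the effect, a lower number that less compound is needed), which is a limit and not a number. Compound 1 `COc1cc(C)nc(OC)c1NC(=O)N(Cc1ccc(Oc2ccc(F)cc2)cc1)C1CCCCCC1` gives 0.032 mg/kg in this assay. Compound 3 `COc1nc(C)ccc1NC(=O)N(Cc1ccc(Oc2ccc(F)cc2)cc1)C1CCCCCC1` carries a 2-methoxy-6-methylpyridin-3-yl group on the amide-type nitrogen instead of the larger group of compound 2 (a group of 9 heavy atoms (7 carbon, 1 nitrogen, 1 oxygen; one six-membered aromatic ring with 1 hetero atom) in place of a group of 12 heavy atoms (7 carbon, 1 nitrogen, 2 oxygen, 1 sulfur, 1 chlorine; one six-membered aromatic ring with 1 hetero atom), on an amide-type nitrogen). Among the compounds with values here, the only measured guide is an at least 3.1-fold higher number from compound 1 to compound 2 (0.49 log units; beyond the scatter), which brought in the very group that now leaves, so a move back to a lower number is expected in this assay. The expected change is an at least 2.0-fold lower number from compound 2 to compound 3 (0.30 log units; that floor lies within the scatter). For compound 3 the estimated value is 0.05 mg/kg, with an expected range of 0.015 mg/kg to 0.16 mg/kg.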

Compound 3, dose for half-maximal effect: > 0.1 mg/kg
Compound 3: a limit, no number; the forecaster's own chance of this, stated with the estimate: 20%; at least 2.0-fold (0.30 log units) between middle value and limit.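

Exchanging one methoxy for hydrogen on an aromatic carbon, with nothing else changed, already gives an at least 3.1-fold higher number from compound 1 to compound 3 (0.49 log units; beyond the scatter) in this assay. A rise of this kind therefore does not require the sulfur and chlorine of the group in compound 2; that one methoxy of compound 1 matters on its own. The step between compound 2 and compound 3 cannot be read, because both values are limits: the limit of > 0.1 mg/kg in this assay, at which 2 of the 3 values shown sit.

Going by these compounds, how much more compound 2 and compound 3 actually need stays open. So does whether an ethoxy or an amine in place of that methoxy would keep the low dose of compound 1.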